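The source may hold more compounds than are shown below. What is called first, only, known or untested is meant among the compounds shown, and "the series" means these compounds.

Working notes on the series. In an in vitro ADME assay on microsomes from liver (Simiiformes) (on this read-out higher numbers stand for a longer-lived compound and lower numbers for a shorter-lived compound), compound 1 `CCc1cc(CCCOc2c(C)cc(-c3noc(C(F)(F)F)n3)cc2C)on1` gives > 2.5 h, which is a limit of the assay and not a number. Going by the values given here, compound 2 `Cc1ccc(CCCOc2c(C)cc(-c3noc(C(F)(F)F)n3)cc2C)cn1` gives 1.97 h, the only actual number so far. Its standing can be read only against compound 1, recorded as the limit of > 2.5 h in this assay, at which 1 of the 2 values shown sits. Among the compounds with values here, the one measured step, an at least 1.2-fold lower number from compound 1 to compound 2 (0.10 log units; that floor lies within the scatter), lies at a different place in the molecule from the change considered here.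

Compound 3 `Cc1ccc(CCCOc2c(C)cc(-c3noc(C)n3)cc2C)cn1` keeps everything else in compound 2 and carries 5-methyl-1,2,4-oxadiazol-3-yl in place of 5-(trifluoromethyl)-1,2,4-oxadiazol-3-yl (methyl in place of trifluoromethyl on an aromatic carbon). Within the data shown here, no measured step touches this place, so the step from compound 1 gives no size to carry over, and the expectation rests on the structural change alone, starting from compound 2 at 1.97 h. A shorter half-life, beyond the scatter, is expected in this assay, though with little certainty about the size. The expected change is a 3.3-fold lower number from compound 2 to compound 3 (0.52 log units; beyond the scatter). For compound 3 the estimated half-life is 0.6 h, with an expected range from 0.2 h to 1.7 h.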

Compound 3, half-life: 1.37 h
The estimate for compound 3 lay 2.3-fold (0.36 log units) below the measured number; low and high end bracket the measured number.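

Going by these compounds alone, this is the first reading at this position. In this assay, the change gives a 1.4-fold lower number from compound 2 to compound 3 (0.16 log units; within the scatter), so compound 2 and compound 3 cannot be told apart on half-life. For the pair carrying 6-methylpyridin-3-yl on the chain, the three fluorine atoms of trifluoromethyl are therefore not needed to hold the half-life at this level, and methyl on the same aromatic carbon serves as well in this read-out. That conclusion rests on this single pair, and compound 1, the only compound with 3-ethyl-1,2-oxazol-5-yl on the chain, is recorded only as a limit of the assay and not a number: the limit of > 2.5 h in this assay, at which 1 of the 3 values shown sits.

Whether methyl in place of trifluoromethyl behaves the same way with 3-ethyl-1,2-oxazol-5-yl on the chain remains open, since the compounds shown hold this change only in the 6-methylpyridin-3-yl setting. How far this carbon of the five-membered ring tolerates other groups, such as an ethyl, a cyclopropyl or an amine, also remains open, as the compounds shown carry only trifluoromethyl and methyl there.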